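Notes on the amine substituent of the shared core

This account rests on a few compounds, and the source may have more. Where it says the series, first, only, none or still open, it means among the compounds named here.

Compound 2 `CCN(c1nc(C)nc2c1nnn2-c1ccc(C(C)C)cc1Br)C(COC)COC` stands at the higher of the two numbers recorded so far in an in vitro assay on 293-EBNA cells for binding affinity to corticotropin-releasing factor receptor 1 (Homo sapiens) (a lower number here means a stronger inhibitor, a higher number a weaker inhibitor), giving 123 nM; compound 1 `Cc1nc(N2CCCCC2)c2nnn(-c3ccc(C(C)C)cc3Br)c2n1`, bearing the six-membered non-aromatic ring with 1 hetero atom on the same aromatic carbon, gives 46 nM. Going by the values given here, the single measured step, a 2.7-fold higher number from compound 1 to compound 2 (0.43 log units; beyond the scatter), shows that exchanging the ring for an acyclic group on that carbon cost a modest amount.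

Compound 3 `CCC(Nc1nc(C)nc2c1nnn2-c1ccc(C(C)C)cc1Br)C(=O)OC` has not been measured. It differs from compound 2 by a group of 8 heavy atoms (5 carbon, 1 nitrogen, 2 oxygen; no ring) in place of a group of 10 heavy atoms (7 carbon, 1 nitrogen, 2 oxygen; no ring), on an aromatic carbon; the entering group brings 1 hydrogen-bond donor and 1 double bond outside aromatic rings, at the carbon next to the ring nitrogen and ortho to a fused ring. Among the compounds with values here, no measured step covers this exchange; only the step from compound 1 to compound 2 touches this position, and it was modest. A change of about the same size or none beyond the scatter is therefore expected, a 1.3-fold higher number from compound 2 to compound 3 (0.11 log units; within the scatter). Compound 3 is estimated at 160 nM, within 50 nM to 500 nM.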

Compound 3, inhibition constant: 19.4 nM
For compound 3 the middle estimate is 8.2-fold (0.92 log units) above the measured one, and the stated range ends above it.
By their numbers in this assay, from the lowest: compound 3; then compound 1; then compound 2.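

Acyclic groups on this aromatic carbon are not confined to numbers above that of the ring-bearing compound: in this assay the earlier step had gone only upward, whereas a 2.4-fold lower number from compound 1 to compound 3 (0.37 log units; beyond the scatter) goes the other way. The group of 8 heavy atoms, which brings 1 hydrogen-bond donor and 1 double bond outside aromatic rings, in place of the group of 10 heavy atoms gives a 6.3-fold lower number from compound 2 to compound 3 (0.80 log units; beyond the scatter), so two acyclic groups at this position differ by more than the ring and the first acyclic group did. No measurement offered here bears on the origin of this change.

From the compounds shown here alone, the exchange alters the heavy-atom count, the donor and the double bond together, so the contribution of each remains open. Also open, going by these compounds, is how a carboxylic acid or a longer chain on the same carbon would read in this assay.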